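This account rests on a few compounds, and the source may have more. Where it says the series, first, only, none or still open, it means among the compounds named here.

Measured so far:
compound 1 `COc1ccc(-c2nc(-c3ccccc3)c(-c3ccc4c(c3)NC(=O)CO4)[nH]2)cc1`: 108%
compound 2 `O=C1COc2ccc(-c3nn(-c4ccc(F)cc4)cc3-c3ccccc3)cc2N1`: 107%

In a functional assay on MV4-11 cells (Homo sapiens) for cytotoxicity, read by colorimetric assay and MTT assay, with a stated time of 3 days, tested at 1 uM (on this read-out lower numbers stand for a stronger effect and higher numbers for a weaker effect at the one concentration tested), compound 1 gives the highest of the two numbers, and compound 2 sits within the usual scatter of it, so the two show no difference worth reading. Compound 3 `O=C1COc2ccc(-c3[nH]c(-c4ccc(F)cc4)nc3-c3ccccc3)cc2N1` is not yet measured. It differs from compound 1 by fluoro in place of methoxy on an aromatic carbon. Among the measured compounds shown here, no step between measured compounds carries this change. Since both measured values lie close together and compound 2 also carries a 4-fluorophenyl group, no step beyond the scatter is expected a number 3 percentage points lower from compound 1 to compound 3 (within the scatter). Compound 3 is estimated at 105% in this assay, expected between 90% and 120%.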

Compound 3, a percentage reported as activity, at one concentration (the size of the read-out at that concentration, not a potency): 108%
The estimate for compound 3 lay 3 percentage points below the measured number, within the range that was stated.
By their numbers in this assay, from the lowest: compounds 2, 1 and 3 (each within the scatter of the next).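

In this assay, among the compounds shown here, the change from 4-methoxyphenyl to 4-fluorophenyl gives no change at the digits printed from compound 1 to compound 3 (within the scatter), and this is the first comparison that differs in one place only. At this position on the aromatic ring, para to a large group, the read-out does not separate methoxy from fluoro on the shared core of compound 1. From the compounds shown here alone, whether an amine or a carboxylic acid at the same carbon would give a step beyond the scatter stays open. Why this step reads as it does also stays open, with no measurement given that bears on it.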